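The source may hold more compounds than are shown below. What is called first, only, known or untested is meant among the compounds shown, and "the series" means these compounds.

In a functional assay on BXPC-3 cells (Homo sapiens) for inhibition, read by XTT assay, with a stated time of 72 h (a higher number here means a weaker inhibitor, a lower number a stronger inhibitor), compound 3 `CCCCCCCC/C=C\CCCCCCCCOC[C@@H]1CCCN1C(=O)[C@@H]1CCCN1C(=O)OC(C)(C)C` gives > 100000 nM, which is a limit of the assay. Compound 1 `CCCCCCCC/C=C\CCCCCCCCOC[C@@H]1CCCN1C(=O)OC(C)(C)C` gives > 100000 nM, also a limit. The step that the two limits leave unreadable from compound 1 to compound 3 therefore offers no guide. Compound 4 `CCCCCCCC/C=C\CCCCCCCCOC[C@@H]1CCCN1C(=O)CN` differs from compound 3 by aminomethyl in place of 1-(tert-butoxycarbonyl)pyrrolidin-2-yl on a carbonyl carbon. Among the compounds with values here, this change removes a tert-butoxycarbonyl group, so the closest precedent is compound 2 `CCCCCCCC/C=C\CCCCCCCCOC[C@@H]1CCCN1`, which gives 5300 nM. Losing tert-butoxycarbonyl on an amine nitrogen in a ring there produced an at least 18-fold lower number from compound 1 to compound 2 (1.27 log units; beyond the scatter). A similarly large fall in the number, towards a stronger inhibitor, is therefore expected, an at least 10-fold lower number from compound 3 to compound 4 (1.00 log units; beyond the scatter). For compound 4 the estimated value is 10000 nM, with an expected range from 2500 nM to 40000 nM.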

Compound 4, half-maximal inhibitory concentration: 5300 nM
Compound 4: the middle estimate sits 1.9-fold (0.28 log units) above what was measured; the measured number falls inside the stated range.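

In this assay, an aminomethyl on this carbonyl carbon gives an at least 18-fold lower number from compound 3 to compound 4 (1.27 log units; beyond the scatter) and also an at least 18-fold lower number from compound 1 to compound 4 (1.27 log units; beyond the scatter), so the ring nitrogen need not be left free for activity to appear. Putting (aminomethyl)carbonyl in place of hydrogen on that nitrogen gives no change at the digits printed from compound 2 to compound 4 (within the scatter), so this group is tolerated where tert-butoxycarbonyl was not. On these data alone, both large steps start from a limit, so their true size is unknown: the limit of > 100000 nM in this assay, at which 2 of the 4 values shown sit.

As far as these compounds go, whether a longer chain between the carbonyl and the amine would keep this level remains open. So does the effect of a carboxylic acid in place of the amine.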